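The source may hold more compounds than are shown below. What is called first, only, known or untested is meant among the compounds shown, and "the series" means these compounds.

Measured compounds:
Compound 1 `COc1cc(NC(=O)Nc2cc(Nc3ccc(C)c(C)c3)ncn2)cc(OC)c1` gives 45.7% in a functional assay on HCC827 cells (Homo sapiens) for inhibition, read by MTT assay, with a stated time of 48 h, tested at 10 uM; on this read-out lower numbers stand for less inhibition and higher numbers for more inhibition at the one concentration tested (going by the name of the read-out).
Compound 2 `Cc1cc(F)cc(Nc2cc(NC(=O)Nc3c(Cl)cccc3Cl)ncn2)c1` gives 49.1% in this assay.

Compound 1 has the smaller of the two numbers shown, with compound 2 as its only neighbour, but the gap between them lies within the scatter of repeated measurements, so on this read-out the two compounds cannot be told apart. Among the compounds with values here, no pair of measured compounds differing in a single place is available, so no measured step sets a scale for what one structural change does here.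

Compound 3 `COc1cc(NC(=O)Nc2cc(Nc3cc(Br)ccc3OC)ncn2)cc(OC)c1` has not yet been measured in this assay. It differs from compound 1 in one place: 5-bromo-2-methoxyphenyl in place of 3,4-dimethylphenyl on a nitrogen on an aromatic ring. With only compound 1 and compound 2 as guides, both sitting close together, the step of a number 0.3 percentage points higher from compound 1 to compound 3 (within the scatter) is expected to be small, with no clear direction, and not beyond the scatter. Compound 3 is therefore estimated to give 46%, within an expected range from 30% to 62%.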

Compound 3, a percentage reported as inhibition, at one concentration (the size of the read-out at that concentration, not a potency): 76.3%
The estimate for compound 3 lay 30.3 percentage points below the measured number; the whole stated range lies below it.
By their numbers in this assay, from the lowest: compounds 1 and 2 (each within the scatter of the next); then compound 3.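

The group on the nitrogen on an aromatic ring is the first place shown to matter in this assay: with the rest of the structure held fixed, 5-bromo-2-methoxyphenyl in place of 3,4-dimethylphenyl brings a number 30.6 percentage points higher from compound 1 to compound 3 (beyond the scatter), the first single-place step available and a large one. This step shows that the read-out can respond strongly to the aryl group at this position, something the two earlier compounds, which differ in more than one place, could not show. Nothing available here bears on why this change has such a large effect.

The change swaps several features at once, so the compounds shown leave open whether the bromine, the methoxy group or their combination carries the step, and whether the removal of the two methyl groups plays any part. They also leave open whether a different group on this ring, such as an amine or a carboxylic acid, would hold the higher number, and whether the same change would have a similar effect on the other urea partner found in compound 2.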